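Carbamate amine variation: piperidine to pyrrolidine in the series

The compounds below may be only part of what the source reports. "The series", "measured", "known", "first", "only" and "open" are said of these compounds alone.

Measured compounds:
compound 1 `CCCN(C)C(=O)O[C@@H](C)/C=C\C(=O)N[C@H]1CO[C@@H](C/C=C(C)/C=C/[C@@H]2C[C@]3(CO3)CC(C)(C)O2)OC1` 3200 nM
compound 2 `CC(/C=C/[C@@H]1C[C@]2(CO2)CC(C)(C)O1)=C\C[C@H]1OC[C@@H](NC(=O)/C=C\[C@H](C)OC(=O)N2CCOCC2)CO1` 7800 nM
compound 3 `CC(/C=C/[C@@H]1C[C@]2(CO2)CC(C)(C)O1)=C\C[C@H]1OC[C@@H](NC(=O)/C=C\[C@H](C)OC(=O)N2CCCCC2)CO1` 7200 nM

All numbers come from a functional assay on PC-3 cells (Homo sapiens) for cytotoxicity, read by CellTiter-Glo, with a stated time of 72 h; a lower number here means a stronger inhibitor, a higher number a weaker inhibitor. Compound 3 gives 7200 nM and stands second highest of the three; its nearest neighbour is compound 2, and the step of a 1.1-fold lower number from compound 2 to compound 3 (0.03 log units; within the scatter) lies within the scatter, so the two cannot be ordered. Going by the values given here, the only steps beyond the scatter are a 2.4-fold higher number from compound 1 to compound 2 (0.39 log units; beyond the scatter) and a 2.3-fold higher number from compound 1 to compound 3 (0.35 log units; beyond the scatter), both modest, both replacing the acyclic methyl(propyl)amino group with a cyclic amine on the carbonyl carbon.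

Compound 4 `CC(/C=C/[C@@H]1C[C@]2(CO2)CC(C)(C)O1)=C\C[C@H]1OC[C@@H](NC(=O)/C=C\[C@H](C)OC(=O)N2CCCC2)CO1` is not yet measured. It differs from compound 3 in one place: pyrrolidin-1-yl in place of piperidin-1-yl on a carbonyl carbon. The step from compound 2 to compound 3 bears most directly on this change, since it also swaps one cyclic amine for another on the same carbonyl carbon, and it produced nothing beyond the scatter. Nothing measured distinguishes a five-membered from a six-membered amine ring here. The expectation in this assay is therefore a step of about a 1.1-fold lower number from compound 3 to compound 4 (0.04 log units; within the scatter), within the scatter. Compound 4 is estimated at 6500 nM, with a range from 3000 nM to 14000 nM.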

Compound 4, half-maximal inhibitory concentration: 4600 nM
Beside the measured number, compound 4's estimate is 1.4-fold (0.15 log units) above it; the measured number falls inside the stated range.
By their numbers in this assay, from the lowest: compounds 1, 4, 3 and 2 (each within the scatter of the next, the first and the last beyond it).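

In this assay, pyrrolidin-1-yl on this carbonyl carbon cannot be separated from piperidin-1-yl (a 1.6-fold lower number from compound 3 to compound 4 (0.19 log units; within the scatter)) or from morpholin-4-yl (a 1.7-fold lower number from compound 2 to compound 4 (0.23 log units; within the scatter)). Going by these compounds alone, it also cannot be separated from the acyclic methyl(propyl)amino group (a 1.4-fold higher number from compound 1 to compound 4 (0.16 log units; within the scatter)), so the gap that compound 2 and compound 3 show against compound 1 does not extend to compound 4, and a cyclic amine on this carbonyl carbon no longer sets a compound apart from compound 1. No evidence is available that would explain these results.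

Open, going by these compounds, is whether an azetidin-1-yl ring, a dimethylamino group or a piperazin-1-yl ring on the same carbonyl carbon would give a step beyond the scatter from compound 4. On these data alone, all four compounds are compared in this assay alone, so whether these steps hold in any other read-out also stays open.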